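The compounds below may be only part of what the source reports. "The series", "measured", "known", "first", "only" and "open" are said of these compounds alone.

Of the compounds shown here, three have so far been measured in a functional assay on U-251 cells (Homo sapiens) for inhibition, read by sulforhodamine B assay, with a stated time of 48 h; on this read-out lower numbers stand for stronger inhibition of growth and higher numbers for weaker inhibition of growth. Compound 1 `COc1ccc(/C=C/C2CC(=O)C=CO2)cc1OC` gives 86.9 uM, compound 2 `COc1ccc(/C=C/c2cc(=O)cco2)cc1OC` gives 339 uM, and compound 3 `COc1ccc(C2CC(=O)C=CO2)cc1` gives 226 uM. On these numbers compound 3 stands second highest of the three: its value lies within the scatter of that of compound 2, whereas compound 1 gives a number beyond the scatter below it. Compound 4 `COc1ccc(C2CC(=O)C(I)=CO2)cc1` has not yet been measured. It differs from compound 3 by iodo in place of hydrogen on a double-bonded ring carbon. Among the measured compounds shown here, no step between measured compounds carries this change, so the data alone do not fix its size. In this assay the step is expected to be a 1.7-fold lower number from compound 3 to compound 4 (0.24 log units; within the scatter), a move toward a lower number that may not clear the scatter. Compound 4 is accordingly estimated at 130 uM, with a range from 40 uM to 400 uM.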

Compound 4, concentration for growth inhibition (reported as GI): 24.4 uM
For compound 4 the middle estimate is 5.3-fold (0.73 log units) above the measured one, and the stated range ends above it.
By their numbers in this assay, from the lowest: compound 4; then compound 1; then compounds 3 and 2 (each within the scatter of the next).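

In this assay iodo in place of hydrogen on a double-bonded ring carbon brings a 9.3-fold lower number from compound 3 to compound 4 (0.97 log units; beyond the scatter) and so shows that this carbon, two ring bonds from the ring oxygen, can take a single heavy atom with a change beyond the scatter. Among the compounds shown here, this is the first step that differs in one place only. Nothing given here accounts for its size.

The compounds shown hold no other group at this carbon, such as chloro, bromo, methyl or a nitrile, so it stays open whether the change is particular to iodo. They also leave open whether iodo at this carbon would act alike on the core of compound 1.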